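Changing the sulfur-linked aryl group and expected cytotoxicity

The source may hold more compounds than are shown below. What is called first, only, known or untested is meant among the compounds shown, and "the series" means these compounds.

Measured so far:
compound 1, `COc1ccc(-c2nc(C[S+]([O-])c3cccc(Cl)c3)nc3ccsc23)cn1`: > 50000 nM
compound 2, `COc1ccc(-c2nc(C3(S(=O)(=O)c4cccc(Cl)c4)CC3)nc3ccsc23)cn1`: > 50000 nM
compound 3, `O=S(=O)(Cc1nc(-c2cccnc2)c2sccc2n1)c1cccc(Cl)c1`: > 50000 nM

In an ADME assay on cells (Homo sapiens) for cytotoxicity, read by resazurin assay, with a stated time of 5 days (on this read-out lower numbers stand for higher toxicity in this test and higher numbers for lower toxicity in this test), compound 1 gives > 50000 nM, and this is a limit of the assay rather than a number. Compound 2 is reported the same way, with > 50000 nM as a limit. Compound 3 is also given only as a limit, > 50000 nM. So compound 1 stands at the limit of > 50000 nM in this assay, at which 3 of the 3 values shown sit, and nothing among the measured compounds separates it from the others. Going by the values given here, no two of the measured compounds differ in just one place, so no measured step can be described.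

Compound 4, `COc1ccc(-c2nc(CSc3ccc(F)cc3F)nc3ccsc23)cn1`, has not yet been tested in this assay. Compared with compound 1 the change is a group of 9 heavy atoms (6 carbon, 2 fluorine, 1 sulfur; one six-membered aromatic ring of carbon only) in place of a group of 9 heavy atoms (6 carbon, 1 oxygen, 1 sulfur, 1 chlorine; one six-membered aromatic ring of carbon only), on a saturated chain carbon bound to an aromatic carbon. Because every measured compound sits at the limit of > 50000 nM in this assay, at which 3 of the 3 values shown sit, there is no evidence that any change of this kind moves the result, and the expectation is a step from compound 1 to compound 4 of about a step that the limit leaves unreadable from compound 1 to compound 4, that is none beyond the usual scatter. Compound 4 is therefore expected to give roughly 60000 nM in this assay, with a likely range from 20000 nM to 200000 nM, and most probably again only a limit.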

Compound 4, half-maximal cytotoxic concentration: > 50000 nM
Compound 4 ended at the assay's limit; the forecaster's own chance of this, stated with the estimate: 85%; the middle value does not contradict the limit.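

In this assay, compound 1 and compound 4 are both reported only as limits of the assay, so the size of any step between them cannot be read: the limit of > 50000 nM in this assay, at which 4 of the 4 values shown sit.

The compounds shown leave open whether any change to the sulfur-linked aryl group can produce a measurable cytotoxic concentration in this test.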